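Aryl exchange from compound 3 to compound 4

The source may hold more compounds than are shown below. What is called first, only, known or untested is meant among the compounds shown, and "the series" means these compounds.

Working notes on the series. In a functional assay on HepG2 cells (Homo sapiens) for cytotoxicity, read by MTT assay, with a stated time of 72 h (on this read-out higher numbers stand for weaker inhibition and lower numbers for stronger inhibition), compound 2 `Cc1cccc(Nc2nc3cnc(Nc4ccc(N5CCN(C)CC5)cc4)nc3n2C2CCCC2)c1` gives 4700 nM and compound 3 `CN1CCN(c2ccc(Nc3ncc4nc(Nc5cccc(Cl)c5)n(C5CCCC5)c4n3)cc2)CC1` gives 4800 nM. Going by the values given here, these are the only two exact numbers available, and they lie within the scatter of each other. Compound 1 `Cc1cc(C)cc(-n2c(Nc3ccccc3)nc3cnc(Nc4ccc(N5CCN(C)CC5)cc4)nc32)c1` is reported only as a limit, > 5000 nM.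

The next compound is compound 4 `CN1CCN(c2ccc(Nc3ncc4nc(Nc5ccc(Br)cc5F)n(C5CCCC5)c4n3)cc2)CC1`. The change is 4-bromo-2-fluorophenyl in place of 3-chlorophenyl on a nitrogen on an aromatic ring, or (4-bromo-2-fluorophenyl)amino for (3-chlorophenyl)amino when cut one bond further out.

Among the compounds with values here, one measured step bears on this change: a 1.0-fold higher number from compound 2 to compound 3 (0.01 log units; within the scatter). It is chloro in place of methyl on an aromatic carbon, within the same aryl group that changes here. The new group differs more from the old one than chloro does from methyl, so this single step is only modest support. Even so, the step within the scatter to compound 3 at 4800 nM gives no ground for expecting a large shift.

The expected step is a 1.2-fold lower number from compound 3 to compound 4 (0.08 log units; within the scatter), with nothing beyond the scatter anticipated. For compound 4 the estimate is 4000 nM, with an expected range of 1800 nM to 7000 nM. A result reported only as a limit is also expected to be possible, given (the limit of > 5000 nM in this assay, at which 1 of the 3 values shown sits).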

Compound 4, half-maximal inhibitory concentration: > 5000 nM
Compound 4 ended at the assay's limit; the forecaster's own chance of this, stated with the estimate: 30%; at least 1.2-fold (0.09 log units) between middle value and limit.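

In this assay, replacing the whole aryl group on the nitrogen gives an at least 1.0-fold higher number from compound 3 to compound 4 (0.01 log units; that floor lies within the scatter), and comparison with the 3-methylphenyl compound gives an at least 1.0-fold higher number from compound 2 to compound 4 (0.02 log units; that floor lies within the scatter); both are floors only, so the true size of each step cannot be read. Compound 4 is reported only as a limit, > 5000 nM, and this shows that a change larger than the earlier swap of chloro for methyl, bringing two halogens onto the ring in a new arrangement, still yields no number that stands clear of the scatter on the side of stronger inhibition. The position on the nitrogen therefore has now taken three different aryl groups without any measured gain in this cytotoxicity read-out, and the result adds a second entry at the top of the range: the limit of > 5000 nM in this assay, at which 2 of the 4 values shown sit.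

The compounds shown leave open how the two halogens act apart, as 4-bromophenyl and 2-fluorophenyl alone would separate them. They also leave open whether an aryl group carrying an amine or a carboxylic acid at this position would give a number clearly lower than those of compound 2 and compound 3.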